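This account rests on a few compounds, and the source may have more. Where it says the series, first, only, none or still open, it means among the compounds named here.

Measured compounds:
compound 1 `O=C(CSc1nnc(Br)n1Cc1ccc(Br)c2ccccc12)NO`, value in an assay on HEK293 cells for inhibition of solute carrier family 22 member 12 (Homo sapiens) (on this read-out lower numbers stand for stronger inhibition and higher numbers for weaker inhibition), 640 nM 
compound 2 `NS(=O)(=O)CSc1nnc(Br)n1Cc1ccc(Br)c2ccccc12`, value in this assay 365000 nM 

In this assay, for the measured compounds named here, compound 2 gives the highest of the two numbers seen; its nearest neighbour is compound 1, and the only step known, a 570-fold higher number from compound 1 to compound 2 (2.76 log units; beyond the scatter), concerns a different change. Compound 3 `O=S(=O)(CSc1nnc(Br)n1Cc1ccc(Br)c2ccccc12)Nc1cccnc1` differs from compound 2 by pyridin-3-yl in place of hydrogen on a sulfonamide nitrogen. Going by the values given here, no measured step touches a sulfonamide nitrogen, so the expectation rests on little. Compound 3 is expected to give a somewhat lower number than compound 2, as a 3.0-fold lower number from compound 2 to compound 3 (0.48 log units; beyond the scatter), with wide uncertainty. The estimate for compound 3 is 120000 nM, ranging from 20000 nM to 500000 nM.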

Compound 3, half-maximal inhibitory concentration: 32 nM
Compound 3: the middle estimate sits 3800-fold (3.57 log units) above what was measured; measured number below the stated range.
By their numbers in this assay, from the lowest: compound 3; then compound 1; then compound 2.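

In this assay, pyridin-3-yl in place of hydrogen on the sulfonamide nitrogen gives an 11000-fold lower number from compound 2 to compound 3 (4.06 log units; beyond the scatter) and shows how strongly this position can shift the read-out. The earlier step made sulfamoyl look like a poor replacement for hydroxycarbamoyl, yet (pyridin-3-yl)sulfamoyl in that place gives a 20-fold lower number from compound 1 to compound 3 (1.30 log units; beyond the scatter) and so a sulfonamide does not by itself rule out a low number.

From the compounds shown here alone, what phenyl or a simple methyl on that nitrogen would give remains open. Nothing available here explains the size of these steps.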